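The source may hold more compounds than are shown below. What is called first, only, known or untested is meant among the compounds shown, and "the series" means these compounds.

Measured compounds:
- compound 1 `COc1cc2ncnc(Nc3ccc(C)cc3)c2cc1OCCCCC(=O)Nc1ccc(S(N)(=O)=O)cc1` — in a functional assay on A549 cells (Homo sapiens) for antiproliferative activity, read by MTT assay, with a stated time of 72 h (on this read-out higher numbers stand for weaker inhibition and lower numbers for stronger inhibition), compound 1 gives > 40000 nM, which is a limit of the assay rather than a number.
- compound 2 `CCc1ccc(Nc2ncnc3cc(OC)c(OCCCCC(=O)Nc4ccc(S(N)(=O)=O)cc4)cc23)cc1` — in this assay compound 2 gives 12100 nM.
- compound 3 `Cc1ccc(Nc2ncnc3ccc(NC(=S)Nc4ccc(S(N)(=O)=O)cc4)cc23)cc1` — in this assay compound 3 gives 2840 nM.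

The change methyl in place of hydrogen on a saturated chain carbon bound to an aromatic carbon produced an at least 3.3-fold lower number from compound 1 to compound 2 (0.51 log units; beyond the scatter); its size is known only as a lower bound because of the limit of > 40000 nM in this assay, at which 1 of the 3 values shown sits. How the core of compound 3 differs from the core of compound 1 is not broken down here.

Compound 4 `CCc1ccc(Nc2ncnc3ccc(NC(=S)Nc4ccc(S(N)(=O)=O)cc4)cc23)cc1` differs from compound 3 by methyl in place of hydrogen on a saturated chain carbon bound to an aromatic carbon, the same change as from compound 1 to compound 2. Since that earlier step was at least modest, a step of similar size is expected here, a 2.8-fold lower number from compound 3 to compound 4 (0.45 log units; beyond the scatter), resting on compound 3 at 2840 nM. Compound 4 is therefore estimated at 1000 nM, expected between 400 nM and 2800 nM.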

Compound 4, half-maximal inhibitory concentration: 24600 nM
For compound 4 the middle estimate is 25-fold (1.39 log units) below the measured one; the measured number lies above the stated range.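

In this assay the change from 4-methylphenyl to 4-ethylphenyl gave an 8.7-fold higher number from compound 3 to compound 4 (0.94 log units; beyond the scatter), so the effect seen on the core of compound 1 did not carry over to the core of compound 3, and the two steps run in opposite directions: the same change on two cores in this assay, an at least 3.3-fold lower number (0.51 log units; beyond the scatter) from compound 1 to compound 2 and an 8.7-fold higher number (0.94 log units; beyond the scatter) from compound 3 to compound 4, at least 28-fold (1.45 log units) apart, beyond the scatter of two such steps. The earlier step is known only as a lower bound, since one of its ends is a limit of the assay and not a number: the limit of > 40000 nM in this assay, at which 1 of the 4 values shown sits. These two pairs show that the outcome of this change depends on the core, but they do not show which difference between the cores is responsible, and they give no general rule.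

As far as these compounds go, it remains open how 4-propylphenyl or 4-methoxyphenyl would behave on each core. From the compounds shown here alone, it also remains open which part of the two cores sets the direction of the step.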